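A few compounds are considered here, and "the series" means these few. Any claim that something is new, unique, unknown or untested is made for them only; others in the source may bear on it.

Working notes on the series built on the shared core of compound 1 `Cc1oc(C(=O)O)cc1COc1ccc(-c2ccc(Cl)cc2)cc1`. In an assay on cells for displacement of a labelled ligand from prostaglandin E2 receptor EP4 subtype (Homo sapiens), read by scintillation counting (on this read-out lower numbers stand for stronger inhibition and higher numbers for weaker inhibition), compound 1 gives 1000 nM, compound 2 `CC(=O)c1ccc(-c2ccc(OCc3cc(C(=O)O)oc3C)cc2)cc1` gives 150 nM, and compound 3 `Cc1oc(C(=O)O)cc1COc1ccc(-c2ccc(CO)cc2)cc1` gives 3000 nM, the highest of the three numbers. Every measured step alters the same group: a 6.7-fold lower number from compound 1 to compound 2 (0.82 log units; beyond the scatter), a 3.0-fold higher number from compound 1 to compound 3 (0.48 log units; beyond the scatter) and a 20-fold higher number from compound 2 to compound 3 (1.30 log units; beyond the scatter). Compound 4 `COc1ccccc1-c1ccc(OCc2cc(C(=O)O)oc2C)cc1` introduces the change (2-methoxyphenyl in place of 4-(hydroxymethyl)phenyl on an aromatic carbon). Among the measured compounds shown here, no measured step removes that group outright or tests a 2-methoxyphenyl, so the steps give only indirect guidance; since compound 3 stands at the weak end, a modest move to a lower number is expected, a 3.0-fold lower number from compound 3 to compound 4 (0.48 log units; beyond the scatter). Compound 4 is estimated at 1000 nM, with a range from 300 nM to 4000 nM.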

Compound 4, inhibition constant: 1600 nM
Estimate against measurement, compound 4: 1.6-fold (0.20 log units) below; measured number inside the range.
By their numbers in this assay, from the lowest: compound 2; then compounds 1, 4 and 3 (each within the scatter of the next, the first and the last beyond it).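

Replacing 4-(hydroxymethyl)phenyl with 2-methoxyphenyl gives a 1.9-fold lower number from compound 3 to compound 4 (0.27 log units; within the scatter), so this exchange, in which the hydrogen-bond donor of the leaving group is absent from the entering group, does not separate the two compounds. Replacing the 4-chlorophenyl gives a 1.6-fold higher number from compound 1 to compound 4 (0.20 log units; within the scatter), which also leaves the two compounds unseparated, so this position tolerates the 2-methoxyphenyl about as well as either of those groups.

Still open, on these data alone, is whether an acetyl or an amine carried on the 2-methoxyphenyl would reach the value of compound 2 at 150 nM. No data here bear on the reason for either step.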